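From One Aromatic Group to Another at a Single Carbon

The source may hold more compounds than are shown below. What is called first, only, known or untested is meant among the compounds shown, and "the series" means these compounds.

Among the compounds with values here, in a functional assay on MCF7 cells (Homo sapiens) for inhibition, read by CCK-8 assay, with a stated time of 48 h (a higher number here means a weaker inhibitor, a lower number a stronger inhibitor), compound 1 `COc1cc(-c2ccnc3cc(-c4ccc(Cl)cc4)nn23)cc(OC)c1OC` gives 2320 nM, while compound 2 `COc1cc(-c2ccnc3cc(-c4ccc5ccn(C)c5c4)nn23)cc(OC)c1OC` gives 74 nM, the lower and therefore stronger of the two numbers so far. Compound 3 `COc1ccc(-c2cc3nccc(-c4cc(OC)c(OC)c(OC)c4)n3n2)cc1N` has not yet been measured. It keeps the core of compound 2 but carries 3-amino-4-methoxyphenyl in place of 1-methyl-1H-indol-6-yl on an aromatic carbon. Within the data shown here, only one measured step bears on this change, at the same carbon: a 31-fold lower number from compound 1 to compound 2 (1.50 log units; beyond the scatter), a large step in which 1-methyl-1H-indol-6-yl replaced 4-chlorophenyl. That single step shows that the group at this carbon can matter greatly in this assay, but it cannot rank the incoming group. A modest rise is therefore expected, with wide uncertainty, as a 1.6-fold higher number from compound 2 to compound 3 (0.21 log units; within the scatter). For compound 3, the estimated value is 120 nM, within an expected range from 18 nM to 800 nM.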

Compound 3, half-maximal inhibitory concentration: 27 nM
Estimate against measurement, compound 3: 4.4-fold (0.65 log units) above, within the range that was stated.
By their numbers in this assay, from the lowest: compound 3; then compound 2; then compound 1.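

In this assay a single six-membered aromatic ring of carbon only is enough at this carbon: the step with 3-amino-4-methoxyphenyl replacing the two-ring 1-methyl-1H-indol-6-yl is a 2.7-fold lower number from compound 2 to compound 3 (0.44 log units; beyond the scatter) and shows that the second ring is not needed for a low number. Having one such ring does not settle the outcome by itself, since compound 1 and compound 3 both have one here, yet the step with 3-amino-4-methoxyphenyl replacing 4-chlorophenyl is an 86-fold lower number from compound 1 to compound 3 (1.93 log units; beyond the scatter) and is large. No measurement at hand explains why these groups differ.

The compounds shown do not separate the contribution of the amino group from that of the methoxy group within 3-amino-4-methoxyphenyl. From the compounds shown here alone, it also remains open whether a hydroxyl group or an acetamide in place of that amino group would keep the number this low.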